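Fluoro to Bromo: Expected Cytotoxicity of Compound 3

This account rests on a few compounds, and the source may have more. Where it says the series, first, only, none or still open, it means among the compounds named here.

Compound 1, `O=C(N/N=C/c1ccccc1)c1cnccn1`: 75%
Compound 2, `O=C(N/N=C/c1ccc(F)cc1)c1cnccn1`: 69%

In an ADME assay on J774 cells (Mus musculus) for cytotoxicity, read by MTT assay, with a stated time of 48 h, tested at 100 ug/mL (a lower number here means a stronger effect, a higher number a weaker effect of the compound at the concentration tested), compound 2 gives the lowest of the two numbers; its nearest neighbour is compound 1, with a step of a number 6 percentage points lower from compound 1 to compound 2 (within the scatter). Compound 3, `O=C(N/N=C/c1ccc(Br)cc1)c1cnccn1`, differs from compound 2 by bromo in place of fluoro on an aromatic carbon. Within the data shown here, the only measured step, a number 6 percentage points lower from compound 1 to compound 2 (within the scatter), also changed a single substituent at the same place and stayed within the scatter, so no step beyond the scatter is expected here, a number 3 percentage points lower from compound 2 to compound 3 (within the scatter). For compound 3 the expected value is 66%, with a range from 50% to 82%.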

Compound 3, a percentage reported as activity, at one concentration (the size of the read-out at that concentration, not a potency): 100%
For compound 3 the middle estimate is 34 percentage points below the measured one; the measured number lies above the stated range.
By their numbers in this assay, from the lowest: compounds 2 and 1 (each within the scatter of the next); then compound 3.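

In this assay, exchanging one halogen for another at this position is not a neutral change: bromo in place of fluoro gives a number 31 percentage points higher from compound 2 to compound 3 (beyond the scatter) and marks a clear loss of effect. Bromo in place of hydrogen likewise gives a number 25 percentage points higher from compound 1 to compound 3 (beyond the scatter), so this position can respond, which the fluoro compound alone did not reveal. Nothing available here explains why bromo behaves differently from fluoro. From the compounds shown here alone, it remains open whether chloro would sit with fluoro or with bromo, and what an amine or a carboxylic acid at this place would give.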